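This account rests on a few compounds, and the source may have more. Where it says the series, first, only, none or still open, it means among the compounds named here.

Measured compounds in a physicochemical assay for permeability, using PAMPA; on this read-out higher numbers stand for higher permeability and lower numbers for lower permeability:
- compound 1 `Cc1oc(-c2c(C)c(C)c(C)c(C)c2C)nc1CN1CCC(C(=O)NCCCN2C[C@H](C)C[C@H](C)C2)CC1` gives 455 10^-6 cm/s
- compound 2 `Cc1ccccc1-c1nc(CN2CCC(C(=O)NCCCN3CC4CCCC(C4)C3)CC2)c(C)o1` gives 331 10^-6 cm/s

For the measured compounds named here, compound 1 has the higher of the two numbers so far, but the only other value, that of compound 2, sits within the scatter of it, so the two are not separable on this read-out. No single-point change between measured compounds is available, so the size of any step in this assay cannot yet be read off from the data themselves.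

The next compound to be measured is compound 3 `COc1ccc(-c2nc(CN3CCC(C(=O)NCCCN4C[C@H](C)C[C@H](C)C4)CC3)c(C)o2)cc1OC`. Relative to compound 1 it carries one change on the shared core: 3,4-dimethoxyphenyl in place of 2,3,4,5,6-pentamethylphenyl on an aromatic carbon

With nothing measured on either side of this change, the expectation rests on the numbers for compound 1 and compound 2 alone. A moderate step downward in this assay is anticipated, of a size that may or may not clear the scatter, with the result most likely staying in the same general region as the two known values rather than collapsing.

Compound 3 is expected to give 250 10^-6 cm/s, within a range of 120 10^-6 cm/s to 450 10^-6 cm/s. The step this implies, a 1.8-fold lower number from compound 1 to compound 3 (0.26 log units; within the scatter), is an estimate only.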

Compound 3, apparent permeability: 81.9 10^-6 cm/s
Compound 3: the middle estimate sits 3.1-fold (0.48 log units) above what was measured; measured number outside the range, below it.
By their numbers in this assay, from the lowest: compound 3; then compounds 2 and 1 (each within the scatter of the next).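

In this assay, for the compounds shown here, this position on the shared core, an aromatic carbon of the five-membered aromatic ring with 1 nitrogen and 1 oxygen, responds to the aryl group it carries: putting 3,4-dimethoxyphenyl in place of 2,3,4,5,6-pentamethylphenyl gives a 5.6-fold lower number from compound 1 to compound 3 (0.74 log units; beyond the scatter), the first single-place step and one that lies beyond the scatter. The counts show that the two groups are close in size, while the entering group brings 2 oxygen atoms and 2 hydrogen-bond acceptors where the leaving group has 0 hydrogen-bond acceptors. No measurement at hand accounts for the step, so the counts only describe the change and do not explain it.

As far as these compounds go, this single step combines the loss of the methyl groups with the gain of the methoxy groups, so the share of each remains open. An unsubstituted phenyl, a phenyl with one methoxy group or a phenyl with fewer methyl groups at this position, each on the core of compound 1, would separate the two parts of the change.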